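The source may report more compounds than this note shows. Statements on the series, on what has been measured and on what is new or still open speak of the compounds shown alone.

Series notes, metabolic stability branch. Compound 1 `COc1cccc(NC(=O)c2nnn(Cc3ccc(-n4cccn4)cc3)c2N)c1` and compound 2 `COc1cccc(NC(=O)c2nnn(Cc3ccc(OC(F)(F)F)cc3)c2N)c1` share one core and differ only at a single aromatic carbon of the benzyl ring. In an ADME assay on microsomes from liver (Mus musculus, strain CD1) for metabolic stability, read by HPLC, using NADPH, with a stated time of 30 min (on this read-out higher numbers stand for fast clearance and lower numbers for slow clearance), compound 1 gives 2.3 mL.min-1.g-1, and in this assay compound 2 gives 2.9 mL.min-1.g-1. Going by the values given here, the only measured step, a 1.3-fold higher number from compound 1 to compound 2 (0.10 log units; within the scatter), lies within the scatter, so compound 2 stands at the higher of the two numbers without being separable from compound 1.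

Next in line is compound 3 `COc1cccc(NC(=O)c2nnn(Cc3ccc(C(C)C)cc3)c2N)c1`, with isopropyl in place of trifluoromethoxy on an aromatic carbon. Among the compounds with values here, no measured step involves isopropyl, and the one step on this ring, a 1.3-fold higher number from compound 1 to compound 2 (0.10 log units; within the scatter), did not move the number beyond the scatter; the bearing of that step on the present change is therefore weak, as it only shows that a swap at this position once left the read-out essentially unchanged. On that basis no step beyond the scatter is expected in this assay, with the middle of the estimate set slightly upward and the range kept wide for want of a relevant comparison. Compound 3 is thus expected to give 3.5 mL.min-1.g-1 in this assay, between 1.8 mL.min-1.g-1 and 8 mL.min-1.g-1. The step this means, a 1.2-fold higher number from compound 2 to compound 3 (0.08 log units; within the scatter), is an expectation only.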

Compound 3, intrinsic clearance in microsomes: 3.2 mL.min-1.g-1
Compound 3: middle estimate off by 1.1-fold (0.04 log units), on the high side; measured number inside the range.
By their numbers in this assay, from the lowest: compounds 1, 2 and 3 (each within the scatter of the next).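

Isopropyl in place of trifluoromethoxy gives a small step in this assay (a 1.1-fold higher number from compound 2 to compound 3 (0.04 log units; within the scatter)), and isopropyl in place of 1H-pyrazol-1-yl also stays small (a 1.4-fold higher number from compound 1 to compound 3 (0.14 log units; within the scatter)), so none of the three groups at this aromatic carbon, para to a large group, can be separated from the others on this read-out. The new change also differs from the earlier one in what is counted: trifluoromethoxy, with 5 heavy atoms and 1 hydrogen-bond acceptor, gives way to isopropyl, with 3 heavy atoms, all carbon, and 0 hydrogen-bond acceptors, and even this exchange produces no step beyond the scatter in these compounds. No accompanying measurement bears on why the three numbers lie so close together.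

From the compounds shown here alone, it remains open whether a primary amine, a carboxylic acid or a longer alkyl chain at this aromatic carbon would give a step beyond the scatter in this assay. The compounds shown also leave open whether replacing the methoxy group elsewhere on the shared core would have any more effect on this read-out than the changes at this position.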